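Two Acid Side Chains on a Shared Sulfonamide Core

The source may hold more compounds than are shown below. What is called first, only, known or untested is meant among the compounds shown, and "the series" means these compounds.

Of the compounds shown here, two have been measured here. Compound 1 `Cc1ccc(S(=O)(=O)N[C@H]2CCC=C2C/C=C\CCC(=O)O)cc1` and compound 2 `O=C(O)COCCCCC1=CCC[C@@H]1NS(=O)(=O)c1ccccc1` share a cyclopentene core bearing a sulfonamide and a side chain that ends in a carboxylic acid. In a functional assay on a cell-free system (plasma) for inhibition of thromboxane A2 receptor (Homo sapiens), read by turbidimetry (on this read-out higher numbers stand for weaker inhibition and lower numbers for stronger inhibition), compound 1 gives 1800 nM, and compound 2 gives 2000 nM. Compound 2 holds the highest of the two numbers, yet its gap to compound 1 lies within the scatter, so the two values show no real difference.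

Compound 3 `O=C(O)CC/C=C\CC1=CCC[C@@H]1NS(=O)(=O)c1ccccc1` keeps the core of compound 2 and changes only the side chain: 4-carboxybut-1-en-1-yl in place of 3-(carboxymethoxy)propyl on a saturated chain carbon bound to a double-bonded ring carbon. No such change between measured compounds has been recorded, so nothing here anchors the size or direction of the step. The acid chain of compound 3 resembles that of compound 1, whose value of 1800 nM sits close to compound 2. The step from compound 2 to compound 3 is therefore expected to stay within the scatter, as a 1.3-fold lower number from compound 2 to compound 3 (0.12 log units; within the scatter). Compound 3 is estimated at 1500 nM, with a likely range from 500 nM to 5000 nM.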

Compound 3, half-maximal inhibitory concentration: 2200 nM
The estimate for compound 3 lay 1.5-fold (0.17 log units) below the measured number, within the range that was stated.
By their numbers in this assay, from the lowest: compounds 1, 2 and 3 (each within the scatter of the next).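

At this position, on a saturated chain carbon bound to a double-bonded ring carbon, 4-carboxybut-1-en-1-yl in place of 3-(carboxymethoxy)propyl gives a 1.1-fold higher number from compound 2 to compound 3 (0.04 log units; within the scatter) in this assay, so this read-out does not tell these two acid chains apart. On an aromatic carbon, hydrogen in place of methyl gives a 1.2-fold higher number from compound 1 to compound 3 (0.09 log units; within the scatter), so this second change also leaves no difference that can be read. Nothing measured here offers an explanation for either result.

As far as these compounds go, all three compounds carry a carboxylic acid, so the effect of an amide or a tetrazole in its place remains open, as does that of a longer chain. On that aromatic carbon only hydrogen and methyl appear, which leaves chlorine and methoxy untested in what is shown.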